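The compounds below may be only part of what the source reports. "The series", "measured", "known", "first", "only" and "open" are said of these compounds alone.

Compound 3 `COc1ccc2c(c1F)C(=O)N(C[C@@]1(c3cc4nc(N5CCNC(=O)C5)ccc4o3)NC(=O)N(COC(=O)C(C)(C)C)C1=O)C2` is one of three compounds examined in an ADME assay on the whole organism for pharmacokinetics, with Rattus norvegicus as the target, read by LC-MS, at a dose of 10 mg/kg by the oral route (a lower number here means less compound in the circulation, a higher number more compound in the circulation at the dose given), and it stands second highest of the three: compound 3 gives 374 ng.h/mL, whereas compound 1 `COc1ccc2c(c1)C(=O)N(C[C@@]1(c3cc4ncccc4o3)NC(=O)N(C(C)C)C1=O)C2` gives 174 ng.h/mL and compound 2 `COc1ccc2c(c1F)C(=O)N(C[C@@]1(c3cc4nc(N5CCN(C)CC5)ccc4o3)NC(=O)N(COC(=O)C(C)(C)C)C1=O)C2` gives 5350 ng.h/mL. Among the measured compounds shown here, the one step that has been measured between close neighbours is a 14-fold lower number from compound 2 to compound 3 (1.16 log units; beyond the scatter), a large movement that follows a change at the amine-bearing position of the bicyclic ring. Compound 4 `COc1ccc2c(c1F)C(=O)N(C[C@@]1(c3cc4nc(N)ccc4o3)NC(=O)N(COC(=O)C(C)(C)C)C1=O)C2` differs from compound 3 at the same position: amino in place of 3-oxopiperazin-1-yl on an aromatic carbon. For the measured compounds named here, no measured step exchanges a ring substituent for a plain amino group, so the only guide is that changing the group at this position shifted exposure considerably between compound 2 and compound 3. Because the earlier shift a 14-fold lower number from compound 2 to compound 3 (1.16 log units; beyond the scatter) ran downward on replacing the basic ring, and the amino group resembles neither of the two rings compared there, the expected step of a 1.1-fold higher number from compound 3 to compound 4 (0.03 log units; within the scatter) is put near zero with wide uncertainty. Compound 4 is therefore expected to give about 400 ng.h/mL in this assay, with a plausible range from 120 ng.h/mL to 1300 ng.h/mL.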

Compound 4, area under the concentration-time curve: 216 ng.h/mL
The estimate for compound 4 lay 1.9-fold (0.27 log units) above the measured number; low and high end bracket the measured number.
By their numbers in this assay, from the lowest: compounds 1, 4 and 3 (each within the scatter of the next, the first and the last beyond it); then compound 2.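

In this assay, the plain amino group and the 3-oxopiperazin-1-yl ring cannot be told apart at this position, next to the ring nitrogen: the step is a 1.7-fold lower number from compound 3 to compound 4 (0.24 log units; within the scatter), so a ring of 7 heavy atoms and a single nitrogen read alike here. Set against the 4-methylpiperazin-1-yl ring, the same amino group gives a 25-fold lower number from compound 2 to compound 4 (1.39 log units; beyond the scatter), which shows that the earlier large step was no peculiarity of the 3-oxopiperazin-1-yl ring, as two very different groups at this place now sit far under compound 2. Among the three compounds that differ only at this position, compound 2 alone stands apart, and nothing shown explains why.

Left open is whether the high number of compound 2 rests on the whole 4-methylpiperazin-1-yl ring or on its methyl group alone, a question that a plain piperazin-1-yl ring, a morpholine ring or an open dimethylamino group at this place would address. Also open, from the compounds shown here alone, is how a longer amine chain or a carboxylic acid on this aromatic carbon would read in this assay.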